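Isopropyl in place of the pivaloyloxymethyl group

The source may hold more compounds than are shown below. What is called first, only, known or untested is meant among the compounds shown, and "the series" means these compounds.

Compound 3 `C[C@@H]1CN(C(=O)c2nc(Nc3cc(C4CC4)[nH]n3)c3cc(Cl)ccc3n2)CCN1C(=O)OCOC(=O)C(C)(C)C` stands second highest of the three compounds measured in an assay for inhibition of serine/threonine-protein kinase PAK 4 (Homo sapiens), read by FRET and Z'-LYTE, with a stated time of 60 min, tested at 0.5 uM, in the presence of a further agent that is not named here; on this read-out higher numbers stand for a stronger effect at the one concentration tested and lower numbers for a weaker effect. In that assay compound 3 gives 0.7%. Its nearest neighbour is compound 2 `C[C@@H]1CN(C(=O)c2nc(Nc3cc(C4CC4)[nH]n3)c3cc(Cl)ccc3n2)CCN1C(=O)OCC(Cl)(Cl)Cl`, which gives -1.5%; the step of a number 2.2 percentage points higher from compound 2 to compound 3 (within the scatter) lies within the scatter. Furthest away is compound 1 `COC(=O)N1CCN(C(=O)c2nc(Nc3cc(C4CC4)[nH]n3)c3cc(Cl)ccc3n2)C[C@H]1C`, which gives 73.9%. Compound 4 `CC(C)OC(=O)N1CCN(C(=O)c2nc(Nc3cc(C4CC4)[nH]n3)c3cc(Cl)ccc3n2)C[C@H]1C` has not yet been measured. Between compound 3 and compound 4 the difference is isopropyl in place of (((tert-butyl)carbonyl)oxy)methyl on an oxygen next to a carbonyl group. Among the compounds with values here, two measured steps bear on this change: a number 75.4 percentage points lower from compound 1 to compound 2 (beyond the scatter) and a number 73.2 percentage points lower from compound 1 to compound 3 (beyond the scatter). Both replace hydrogen on a saturated chain carbon bound to an oxygen next to a carbonyl group with a group of many heavy atoms, and both lose nearly all of the inhibition seen in compound 1. Compound 4 removes the eight-atom group of compound 3 and carries an isopropyl, three carbons, on the oxygen next to the carbonyl group. Within the data shown here, no measured compound carries an isopropyl there, so the outcome is uncertain. A rise is expected, estimated as a number 44.3 percentage points higher from compound 3 to compound 4 (beyond the scatter), because compound 1 with only hydrogen at that place gives 73.9%. Compound 4 is therefore estimated to give 45%, within a range from 5% to 78%.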

Compound 4, a percentage reported as inhibition, at one concentration (the size of the read-out at that concentration, not a potency): 26.9%
Compound 4: the middle estimate sits 18.1 percentage points above what was measured, within the range that was stated.
By their numbers in this assay, from the lowest: compounds 2 and 3 (each within the scatter of the next); then compound 4; then compound 1.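

Isopropyl on an oxygen next to a carbonyl group restores part of the effect in this assay: the result is a number 26.2 percentage points higher from compound 3 to compound 4 (beyond the scatter), and likewise a number 28.4 percentage points higher from compound 2 to compound 4 (beyond the scatter), so the near-total loss seen with (((tert-butyl)carbonyl)oxy)methyl and 2,2,2-trichloroethyl does not extend to every group larger than methyl. Within the data shown here, the recovery is only partial, however, with a number 47 percentage points lower from compound 1 to compound 4 (beyond the scatter), which shows that this position already responds to the change from methyl to isopropyl, a sensitivity that the earlier compounds, with their single large drop, could not resolve. The four compounds now fall into three levels, with compound 1 above compound 4 and compound 4 above compound 2 and compound 3, although nothing shown explains this order.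

Going by these compounds, it remains open where an ethyl group would fall relative to methyl and isopropyl, and whether a straight propyl chain would match the branched isopropyl. Also open, on these data alone, is whether a dimethylamino group in place of isopropoxy would keep any of this effect, and how any of these readings at one concentration would translate into potency.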